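The compounds below may be only part of what the source reports. "The series", "measured", "known", "first", "only" and "open" are said of these compounds alone.

The measured compounds, in a functional assay on A549 cells (Homo sapiens) for inhibition, read by MTT assay, with a stated time of 72 h; on this read-out higher numbers stand for weaker inhibition and lower numbers for stronger inhibition:
compound 1 `COc1cc2c(Oc3ccc(NC(=O)c4nn(-c5ccccc5C(F)(F)F)c(=O)cc4C)cc3F)ccnc2cc1OCCCN1CCCC1`, 130 nM
compound 2 `COc1cc2c(Oc3ccc(NC(=O)c4nn(-c5ccccc5C(F)(F)F)c(=O)cc4C)cc3F)ccnc2cc1OCCCN1CCC(C)CC1`, 160 nM
compound 3 `COc1cc2c(Oc3ccc(NC(=O)c4nn(-c5ccccc5C(F)(F)F)c(=O)cc4C)cc3F)ccnc2cc1OCCCN1CCN(C)CC1`, 170 nM

Compound 1 holds the lowest of the three numbers, but it cannot be set apart from the other two: the step of a 1.2-fold higher number from compound 1 to compound 2 (0.09 log units; within the scatter) and the step of a 1.3-fold higher number from compound 1 to compound 3 (0.12 log units; within the scatter) both lie within the scatter, and so does the step of a 1.1-fold higher number from compound 2 to compound 3 (0.03 log units; within the scatter). The three compounds share one core and differ only in the amine at the end of the chain that hangs from the aromatic oxygen, and that amine has no visible effect on this read-out.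

Compound 4 `COc1cc2c(Oc3ccc(NC(=O)c4nn(-c5ccc(F)c(F)c5)c(=O)cc4C)cc3F)ccnc2cc1OCCCN1CCCC1` takes a different route. It keeps the pyrrolidin-1-yl end of compound 1 and changes the other end of the molecule: 3,4-difluorophenyl in place of 2-(trifluoromethyl)phenyl on an aromatic nitrogen. For the measured compounds named here, none of the three measured steps touches this aromatic nitrogen, so no measured step bears on the change, and the expectation rests on compound 1 alone, with a wide allowance for the unknown. Compound 4 is therefore estimated at 200 nM, with a range of 60 nM to 700 nM. That estimate means an expected step of a 1.5-fold higher number from compound 1 to compound 4 (0.19 log units; within the scatter), which is not beyond the scatter.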

Compound 4, half-maximal inhibitory concentration: 220 nM
Compound 4: the middle estimate sits 1.1-fold (0.04 log units) below what was measured; measured number inside the range.
By their numbers in this assay, from the lowest: compounds 1, 2, 3 and 4 (each within the scatter of the next).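

In this assay the replacement of 2-(trifluoromethyl)phenyl by 3,4-difluorophenyl on the aromatic nitrogen gives a 1.7-fold higher number from compound 1 to compound 4 (0.23 log units; within the scatter), so this step lies within the scatter. For the compounds shown here, it is the first reading at this end of the molecule, and it shows that this exchange of one fluorinated phenyl group for another cannot be told from no change, as was already true of the amine exchanges at the far end of the chain. No separate measurement on these compounds bears on the result, so nothing can be said about what lies behind it.

This single exchange leaves open how far the position stays this flat, for instance with an unsubstituted phenyl, a 4-fluorophenyl, a pyridyl ring or a small alkyl group such as methyl on the aromatic nitrogen. Also open, going by these compounds, is whether 3,4-difluorophenyl would read the same with a 4-methylpiperazin-1-yl or 4-methylpiperidin-1-yl end on the chain, or whether the two ends would begin to act together.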